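A larger group on the shared core

The source may report more compounds than this note shows. Statements on the series, on what has been measured and on what is new or still open speak of the compounds shown alone.

Of the compounds shown here, three with one core have been measured in a functional assay on aorta (Rattus norvegicus, strain Sprague-Dawley); a lower number here means that less compound is needed, a higher number that more compound is needed for the effect. Compound 1 `Cc1nn(-c2ccccc2)c2nc(OCc3ccccc3F)c(-c3nc(N)cc(N)n3)cc12` gives 2200 nM, compound 2 `Cc1nn(-c2ccccc2)c2nc(OCc3ccccc3F)c(-c3nc(N)c(N(C)C)c(N)n3)cc12` gives 1100 nM, and compound 3 `Cc1nn(-c2ccccc2)c2nc(OCc3ccccc3F)c(-c3nc(N)c(N)c(N)n3)cc12` gives 960 nM. Compound 3 cannot be told apart from compound 2, as a 1.1-fold lower number from compound 2 to compound 3 (0.06 log units; within the scatter) shows. Compound 3 does stand clear of compound 1, though only just, while a 2.0-fold lower number from compound 1 to compound 2 (0.30 log units; within the scatter) does not clear the scatter.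

Compound 4 `Cc1nn(-c2ccccc2)c2nc(OCc3ccccc3F)c(-c3nc(N)c4c(n3)[nH]c(=O)n4C)cc12` has not yet been measured. Compared with compound 3, it carries a group of 12 heavy atoms (6 carbon, 5 nitrogen, 1 oxygen; one five-membered aromatic ring with 2 hetero atoms, one six-membered aromatic ring with 2 hetero atoms) in place of a group of 9 heavy atoms (4 carbon, 5 nitrogen; one six-membered aromatic ring with 2 hetero atoms), on an aromatic carbon. The 4,5,6-triaminopyrimidin-2-yl group leaves, and the new group takes its place on an aromatic carbon, ortho to the (2-fluorobenzyl)oxy group.

The measured steps are only a weak guide here. Among the compounds with values here, each exchanged one small group within the 4,5,6-triaminopyrimidin-2-yl group or its close relative, whereas compound 4 replaces the whole group, and no measured compound carries a second ring there. Even the one step beyond the scatter, a 2.3-fold lower number from compound 1 to compound 3 (0.36 log units; beyond the scatter), is modest, so no step beyond the scatter is expected in this assay, although a surprise in either direction remains possible. The expected step is a 1.3-fold higher number from compound 3 to compound 4 (0.10 log units; within the scatter). For compound 4 the estimated value is 1200 nM, with an expected range of 350 nM to 4000 nM.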

Compound 4, half-maximal effective concentration: 4900 nM
The estimate for compound 4 lay 4.1-fold (0.61 log units) below the measured number; the whole stated range lies below it.
By their numbers in this assay, from the lowest: compounds 3, 2 and 1 (each within the scatter of the next, the first and the last beyond it); then compound 4.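

Within the data shown here, exchanging the whole 4,5,6-triaminopyrimidin-2-yl group for a two-ring group is the first change at this position to give a higher number in this assay, with a 5.1-fold higher number from compound 3 to compound 4 (0.71 log units; beyond the scatter). The same comparison with the two other groups points the same way, with a 4.5-fold higher number from compound 2 to compound 4 (0.65 log units; beyond the scatter) and a 2.2-fold higher number from compound 1 to compound 4 (0.35 log units; beyond the scatter), so compound 4 has the highest number of the four, beyond the scatter of each of the others. The position therefore does respond to what is placed there: small exchanges on the single six-membered aromatic ring shifted the number little or only modestly, whereas this larger exchange moved it upward, though still by a modest step.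

Because the new group brings a second ring, a carbonyl and a methyl group all at once, the compounds shown leave open which of these parts goes with the higher number, and also how a plain phenyl ring would behave at this position. No measurement is available here that explains the rise.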